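A few compounds are considered here, and "the series" means these few. Any claim that something is new, unique, unknown or untested is made for them only; others in the source may bear on it.

Measured so far in a functional assay on CHO cells for antagonist activity at adenosine receptor A2b (Homo sapiens), read by 33P incorporation, with a stated time of 20 min; on this read-out lower numbers stand for stronger inhibition and higher numbers for weaker inhibition:

compound 1, `CCn1c(-c2ccccc2)nc2c(NC3CCC3)ncnc21` — 1440 nM
compound 2, `CCn1c(-c2ccccc2)nc2c(N)ncnc21` — 3020 nM
compound 3, `Cn1c(-c2ccccc2)nc2c(NC3CCCC3)ncnc21` — 8510 nM

Compound 3 stands highest of the three numbers in this assay, so it is the weakest of the three. Compound 2 lies nearest to it, with its value of 3020 nM. Compound 1 lies furthest from it, with its value of 1440 nM, and both of those gaps are beyond the scatter.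

Compound 4, `CCn1c(-c2ccccc2)nc2c(NC3CCCC3)ncnc21`, differs from compound 3 by methyl in place of hydrogen on a saturated chain carbon bound to an aromatic nitrogen. Among the measured compounds shown here, the one measured single-point step, a 2.1-fold higher number from compound 1 to compound 2 (0.32 log units; beyond the scatter), concerns the group on the amine nitrogen and not the group on the aromatic nitrogen, so it bears only indirectly on the present change. Compound 1 and compound 3 differ in two places, the chain on the aromatic nitrogen and the ring on the amine nitrogen, and their values show a wide gap; compound 4 shares the ethyl of compound 1 and the cyclopentyl of compound 3, so it should fall between them. A downward step beyond the scatter is therefore expected, a 3.4-fold lower number from compound 3 to compound 4 (0.53 log units; beyond the scatter), in this assay. For compound 4 the estimate is 2500 nM, within a range of 900 nM to 7000 nM.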

Compound 4, inhibition constant: 5790 nM
The estimate for compound 4 lay 2.3-fold (0.36 log units) below the measured number; the range from low to high includes it.
By their numbers in this assay, from the lowest: compound 1; then compounds 2, 4 and 3 (each within the scatter of the next, the first and the last beyond it).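

In this assay, methyl in place of hydrogen on a saturated chain carbon bound to an aromatic nitrogen, read with cyclopentyl held fixed on the other nitrogen, gives a 1.5-fold lower number from compound 3 to compound 4 (0.17 log units; within the scatter), so methyl and ethyl at this position are not told apart in this pair. With ethyl held fixed, the readable difference lies on the nitrogen on an aromatic ring: cyclopentyl in place of cyclobutyl gives a 4.0-fold higher number from compound 1 to compound 4 (0.60 log units; beyond the scatter), whereas cyclopentyl in place of hydrogen gives only a 1.9-fold higher number from compound 2 to compound 4 (0.28 log units; within the scatter), and hydrogen in place of cyclobutyl gives a 2.1-fold higher number from compound 1 to compound 2 (0.32 log units; beyond the scatter), so among these three ethyl compounds cyclobutyl alone stands apart. The data at hand offer no explanation for either result.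

Going by these compounds, a propyl or longer chain on the saturated position bound to the aromatic nitrogen remains open, as does whether the chain stays without a readable effect once that position carries a hydroxyl or an amine. On these data alone, on the nitrogen on an aromatic ring, cyclopropyl and cyclohexyl remain open, as does whether cyclobutyl keeps its separate place when methyl replaces ethyl.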